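From 2-hydroxyethyl to benzoyl on one oxygen

The source may hold more compounds than are shown below. What is called first, only, known or untested is meant among the compounds shown, and "the series" means these compounds.

Measured in an ADME assay on HEK293 cells (Homo sapiens) for cytotoxicity, read by resazurin assay, with a stated time of 16 h; on this read-out lower numbers stand for an effect already at smaller amounts and higher numbers for an effect only at larger amounts of compound
- compound 1 `C=CCOc1ccc(/C=C/C(=O)CC(=O)/C=C/c2ccc(O)c(OC)c2)cc1OC` gives 270000 nM
- compound 2 `COc1cc(/C=C/C(=O)CC(=O)/C=C/c2ccc(OCC=C(C)C)c(OC)c2)ccc1O` gives > 500000 nM which is a limit of the assay
- compound 3 `COc1cc(/C=C/C(=O)CC(=O)/C=C/c2ccc(OCCO)c(OC)c2)ccc1O` gives 25000 nM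

Compound 3 has the lowest number here, with a step of an 11-fold lower number from compound 1 to compound 3 (1.03 log units; beyond the scatter) and a step of an at least 20-fold lower number from compound 2 to compound 3 (1.30 log units; beyond the scatter) pointing the same way. For the measured compounds named here, compound 4 `COc1cc(/C=C/C(=O)CC(=O)/C=C/c2ccc(OC(=O)c3ccccc3)c(OC)c2)ccc1O` has benzoyl in place of 2-hydroxyethyl on an oxygen on an aromatic ring as its only change. Both steps changed the group on this same oxygen, and compound 4 loses the 2-hydroxyethyl that separates compound 3 from compound 1 at 270000 nM in the data. Benzoyl itself is unmeasured, so a smaller upward move is expected, namely a 4.0-fold higher number from compound 3 to compound 4 (0.60 log units; beyond the scatter) as an estimate. The estimated value for compound 4 is 100000 nM with an expected range from 20000 nM to 400000 nM.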

Compound 4, half-maximal effective concentration: 94000 nM
Estimate against measurement, compound 4: 1.1-fold (0.03 log units) above, within the range that was stated.
By their numbers in this assay, from the lowest: compound 3; then compound 4; then compound 1. At a limit, above all of these: compound 2.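

In this assay, a ring-bearing group on this oxygen lands inside the spread of the chain groups, with a 3.8-fold higher number from compound 3 to compound 4 (0.58 log units; beyond the scatter) and a 2.9-fold lower number from compound 1 to compound 4 (0.46 log units; beyond the scatter), so removing the 2-hydroxyethyl does not by itself restore the number of the allyl compound. The prenyl-type chain also stays clearly apart, with an at least 5.3-fold lower number from compound 2 to compound 4 (0.72 log units; beyond the scatter). Compound 2 sits at a limit, so that step is only a floor: the limit of > 500000 nM in this assay, at which 1 of the 4 values shown sits.

Going by these compounds, whether benzyl, which keeps the ring without the carbonyl, would behave like benzoyl stays open. So does whether an amine or a carboxylic acid on this oxygen would give a lower number than compound 3.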